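The source may hold more compounds than are shown below. What is called first, only, known or untested is meant among the compounds shown, and "the series" means these compounds.

Measured in a functional assay on the whole organism (brain) with Mus musculus as the target; on this read-out lower numbers stand for an effect already at smaller amounts and higher numbers for an effect only at larger amounts of compound:
- compound 1 `O=[N+]([O-])c1ccc(OCCc2c[nH]cn2)cc1`: 0.66 mg/kg
- compound 2 `N#Cc1cccc(OCCc2c[nH]cn2)c1`: 2.9 mg/kg
- compound 3 `O=C(c1ccc(OCCc2c[nH]cn2)cc1)N1CCCCC1`: > 10 mg/kg (a limit)

Compound 1 has the lower of the two numeric values, and compound 2 lies higher, beyond the scatter. The result for compound 3 is a limit, not a number: the limit of > 10 mg/kg in this assay, at which 1 of the 3 values shown sits.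

The next compound is compound 4 `Clc1ccc(OCCc2c[nH]cn2)cc1`, with chloro in place of nitro on an aromatic carbon. For the measured compounds named here, no measured pair isolates this change, so the expectation is tentative: a small move toward a higher number, probably within the scatter. The expected change is a 1.8-fold higher number from compound 1 to compound 4 (0.26 log units; within the scatter). For compound 4 the estimated value is 1.2 mg/kg, with an expected range of 0.3 mg/kg to 5 mg/kg.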

Compound 4, dose for half-maximal effect: 0.78 mg/kg
Estimate against measurement, compound 4: 1.5-fold (0.19 log units) above; the range from low to high includes it.
By their numbers in this assay, from the lowest: compounds 1 and 4 (each within the scatter of the next); then compound 2. At a limit, above all of these: compound 3.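

In this assay, chloro in place of nitro, on an aromatic carbon para to a group of 8 heavy atoms, gives a 1.2-fold higher number from compound 1 to compound 4 (0.07 log units; within the scatter). This position therefore accepts a change from 3 heavy atoms to 1 without a step beyond the scatter. The 2 hydrogen-bond acceptors of nitro are also not needed here for a number this low.

Going by these compounds, whether an amine, a carboxylic acid or a methoxy group at this position would read the same remains open. Nothing shown bears on why nitro and chloro read alike.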